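Sulfonylpiperidines Against Colon Cancer Cells: Changing the Amine

This account rests on a few compounds, and the source may have more. Where it says the series, first, only, none or still open, it means among the compounds named here.

compound 1 `Cc1ccc(C2CCN(S(=O)(=O)c3c(C)cc(C)cc3C)CC2)cc1` gives 2200 nM
compound 2 `Cc1cc(C)c(S(=O)(=O)N2CCC(N3CCN(C)CC3)CC2)c(C)c1` gives 1100 nM

In a functional assay on DLD-1 cells (Homo sapiens) for antiproliferative activity, read by CellTiter-Glo, with a stated time of 72 h (a higher number here means a weaker inhibitor, a lower number a stronger inhibitor), compound 2 and compound 1 give numbers within the scatter of each other, since the step of a 2.0-fold lower number from compound 1 to compound 2 (0.30 log units; within the scatter) is within the scatter. Compound 3 `Cc1cc(C)c(S(=O)(=O)N2CCC(N3CCCCCC3)CC2)c(C)c1` differs from compound 2 by azepan-1-yl in place of 4-methylpiperazin-1-yl on a saturated ring carbon. Within the data shown here, no measured step covers this change; the single step on record, a 2.0-fold lower number from compound 1 to compound 2 (0.30 log units; within the scatter), shows that a different group at this saturated ring carbon left the number nearly unchanged. For compound 3 a step no larger than the scatter is therefore expected: a 1.4-fold higher number from compound 2 to compound 3 (0.13 log units; within the scatter). Compound 3 is estimated at 1500 nM, within 400 nM to 6000 nM.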

Compound 3, half-maximal inhibitory concentration: 5.3 nM
For compound 3 the middle estimate is 280-fold (2.45 log units) above the measured one; the whole stated range lies above it.
By their numbers in this assay, from the lowest: compound 3; then compounds 2 and 1 (each within the scatter of the next).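

At this saturated ring carbon, the choice of group matters far more than the earlier pair suggested. In this assay azepan-1-yl gives a 210-fold lower number from compound 2 to compound 3 (2.32 log units; beyond the scatter) even though both groups have 7 heavy atoms, and measured against 4-methylphenyl it gives a 420-fold lower number from compound 1 to compound 3 (2.62 log units; beyond the scatter) as well. The close numbers of the first two compounds therefore did not mean that this position accepts any group. No measured evidence accounts for this large gain. Also open, from the compounds shown here alone, is whether ring size or the hetero atom count matters more, a question that piperidin-1-yl could help to separate.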